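This account rests on a few compounds, and the source may have more. Where it says the series, first, only, none or still open, it means among the compounds named here.

Compound 1, `CC1(C)CC(=S)Nc2ccc(Cl)cc21`, gives 85.7% in a functional assay on MDA-MB-231 cells (Homo sapiens) for cytotoxicity, read by MTT assay, with a stated time of 72 h, tested at 1 uM, in the absence of a further agent; a lower number here means a stronger effect, a higher number a weaker effect of the compound at the concentration tested.
Compound 2, `CC1(C)CC(N)=Nc2ccc(Cl)cc21`, gives 80.5% in this assay.
Compound 3, `CCNC1=Nc2ccc(Cl)cc2C(C)(C)C1`, gives 89.7% in this assay.

All three share one core and differ only at the group attached to it. Compound 3 stands alongside the other two rather than apart from them: the step of a number 9.2 percentage points higher from compound 2 to compound 3 (within the scatter) is within the scatter, and the gap between compound 1 and compound 3 is within the scatter as well, so the three numbers read as a single level, with none of the compounds reducing cell viability strongly at this concentration.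

Compound 4, `CN(C)CCNC1=Nc2ccc(Cl)cc2C(C)(C)C1`, carries the change (dimethylamino in place of hydrogen on a saturated chain carbon, two bonds along the chain from an amine nitrogen). Within the data shown here, the only measured step touching this part of the molecule is the one from hydrogen to ethyl on the amine nitrogen, a number 9.2 percentage points higher from compound 2 to compound 3 (within the scatter), which was within the scatter. Extending that chain further with a dimethylamino group therefore has no measured precedent that points in either direction, and the expectation in this assay is a step no larger than the scatter.

Compound 4 is thus expected to give 88%, with a range from 74% to 100%. The estimated step of a number 1.7 percentage points lower from compound 3 to compound 4 (within the scatter) is expected to stay within the scatter.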

Compound 4, a percentage reported as activity, at one concentration (the size of the read-out at that concentration, not a potency): 66.9%
For compound 4 the middle estimate is 21.1 percentage points above the measured one; measured number below the stated range.
By their numbers in this assay, from the lowest: compound 4; then compounds 2, 1 and 3 (each within the scatter of the next).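

Hydrogen to ethyl on the amine nitrogen left the number in this assay at the same level, with a number 9.2 percentage points higher from compound 2 to compound 3 (within the scatter), so this part of the molecule had looked unresponsive. Dimethylamino in place of hydrogen on a saturated chain carbon, two bonds along the chain from an amine nitrogen, is the first change here to give a shift larger than the scatter, with a number 22.8 percentage points lower from compound 3 to compound 4 (beyond the scatter), and a lower number means a stronger effect at the concentration tested; the full 2-(dimethylamino)ethyl group, compared with the bare hydrogen on the amine nitrogen, gives the same picture, with a number 13.6 percentage points lower from compound 2 to compound 4 (beyond the scatter), so the shift appears against both neighbouring compounds, although its size stays modest. Nothing measured here explains the shift, and no structural or physical data on these compounds accompany the numbers.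

The compounds shown leave open whether the dimethylamino group itself matters or whether another end group on the ethyl chain, such as a hydroxyl, a morpholine or a pyrrolidine, would serve equally well. They also leave open how the result would change with a longer chain, such as 3-(dimethylamino)propyl, and, with one concentration only, how potent compound 4 actually is.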